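From 3-methylphenyl to 2-fluorophenyl on a shared core

The compounds below may be only part of what the source reports. "The series", "measured", "known", "first", "only" and "open" are said of these compounds alone.

- Compound 1 `COc1ccc(F)cc1N1C(=O)CSC1c1cccc(C(=O)NCCCCn2cccn2)c1` gives 50000 nM
- Compound 2 `Cc1cccc(N2C(=O)CSC2c2cccc(C(=O)NCCCCc3ccccc3)c2)c1` gives 10000 nM

In a physicochemical assay for solubility, read by turbidimetry, measured as kinetic solubility, at pH 7.4 (on this read-out higher numbers stand for higher solubility and lower numbers for lower solubility), only these two compounds have numbers, and compound 2 holds the lower one, a gap from compound 1 that lies beyond the usual scatter. The two differ in more than one place, so their gap cannot be tied to any single change. Compound 3 `O=C(NCCCCc1ccccc1)c1cccc(C2SCC(=O)N2c2ccccc2F)c1` departs from compound 2 at one place only: 2-fluorophenyl in place of 3-methylphenyl on an amide-type nitrogen in a ring. In words, 2-fluorophenyl stands in place of 3-methylphenyl on an amide-type nitrogen in a ring. For the measured compounds named here, no measured pair shows this change, so the estimate stays close to compound 2 at 10000 nM. The expected change is a 1.2-fold higher number from compound 2 to compound 3 (0.08 log units; within the scatter), an estimated shift that stays within the scatter, with no clear direction. In this assay compound 3 is expected at 12000 nM (estimated range 5000 nM to 30000 nM).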

Compound 3, solubility: 10000 nM
Estimate against measurement, compound 3: 1.2-fold (0.08 log units) above; the measured number falls inside the stated range.
By their numbers in this assay, from the lowest: compounds 2 and 3 (each within the scatter of the next); then compound 1.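

In this assay, for the compounds shown here, compounds 2 and 3 give the first comparison in which only one place differs, so their result can be tied to a single change. The step shows no change at the digits printed from compound 2 to compound 3 (within the scatter) when 2-fluorophenyl takes the place of 3-methylphenyl on an amide-type nitrogen in a ring. The two groups match in heavy atoms and aromatic ring type, and they differ in that one carbon is replaced by fluorine, so this one exchange at this position leaves the read-out unmoved.

Still open, from the compounds shown here alone, is how the read-out responds at this position to a group of a different kind, such as a phenyl ring carrying an amine or a carboxylic acid, or a longer chain in place of the ring. No measurement at hand tells why these two groups read alike.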